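Methoxy for methyl on an aromatic carbon

This account rests on a few compounds, and the source may have more. Where it says the series, first, only, none or still open, it means among the compounds named here.

In a functional assay on HCT-15 cells (Homo sapiens) for antiproliferative activity, read by MTT assay, with a stated time of 72 h (a higher number here means a weaker inhibitor, a lower number a stronger inhibitor), compound 1 `CCCCn1ccnc1-c1cc(OC)c(OC)c(OC)c1` gives > 100000 nM, which is a limit of the assay. Compound 2 `CCCCCn1ccnc1-c1cc(OC)c(OC)c(OC)c1` gives > 100000 nM, also a limit. Among the compounds with values here, compound 3 `COc1cc(-c2nccn2-c2cccc(C)c2)cc(OC)c1OC` gives 1600 nM, the only actual number so far. Placing 3-methylphenyl on the aromatic nitrogen in place of butyl gave an at least 62-fold lower number from compound 1 to compound 3 (1.79 log units; beyond the scatter), and in place of pentyl it gave an at least 62-fold lower number from compound 2 to compound 3 (1.79 log units; beyond the scatter). Compound 4 `COc1cccc(-n2ccnc2-c2cc(OC)c(OC)c(OC)c2)c1` has methoxy in place of methyl on an aromatic carbon, meta to a large group (methoxy in place of methyl on an aromatic carbon). Within the data shown here, those large steps replaced a whole chain, whereas this change is a small edit, and no measured step tests it. The expected result is a 1.1-fold higher number from compound 3 to compound 4 (0.05 log units; within the scatter), with no change beyond the scatter. Compound 4 is estimated at 1800 nM, with an expected range of 450 nM to 7000 nM.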

Compound 4, half-maximal inhibitory concentration: 17100 nM
The estimate for compound 4 lay 9.5-fold (0.98 log units) below the measured number, and the stated range ends below it.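

On this aromatic carbon, the swap of methyl for methoxy is not a small edit: in this assay it gives an 11-fold higher number from compound 3 to compound 4 (1.03 log units; beyond the scatter). The 3-methoxyphenyl group still beats both chains on the aromatic nitrogen, with an at least 5.8-fold lower number from compound 2 to compound 4 (0.76 log units; beyond the scatter) and an at least 5.8-fold lower number from compound 1 to compound 4 (0.76 log units; beyond the scatter). Those two steps are bounds rather than exact sizes: the limit of > 100000 nM in this assay, at which 2 of the 4 values shown sit.

As far as these compounds go, only methyl and methoxy are compared on this carbon, so the effect of a hydroxyl, an amine or an ethyl group there remains open. So does the result of moving either group to another carbon of the ring.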